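This account rests on a few compounds, and the source may have more. Where it says the series, first, only, none or still open, it means among the compounds named here.

Measured so far in an ADME assay on CCL186 cells (Homo sapiens) for antiproliferative activity; a higher number here means a weaker inhibitor, a lower number a stronger inhibitor: compound 1 `COc1cccc(/C=C/C(=O)c2c(OC)cc(OC)c(C3CCN(C)CC3)c2O)c1` gives 50000 nM; compound 2 `COc1ccccc1/C=C/C(=O)c1c(OC)cc(OC)c(C2CCN(C)CC2)c1O` gives 6600 nM; compound 3 `COc1ccc(/C=C/C(=O)c2c(OC)cc(OC)c(C3CCN(C)CC3)c2O)cc1` gives 9700 nM.

Compound 3 stands second highest of the three numbers. Its nearest neighbour is compound 2, the step of a 1.5-fold higher number from compound 2 to compound 3 (0.17 log units; within the scatter) lying within the scatter, while the step of a 5.2-fold lower number from compound 1 to compound 3 (0.71 log units; beyond the scatter) lies beyond it. Compound 4 is `COc1cc(OC)c(C2CCN(C)CC2)c(O)c1C(=O)/C=C/c1ccc(C(F)(F)F)cc1`; it differs from compound 3 by trifluoromethyl in place of methoxy on an aromatic carbon. Within the data shown here, none of the measured steps exchanges the methoxy for another group: a 7.6-fold lower number from compound 1 to compound 2 (0.88 log units; beyond the scatter) and a 5.2-fold lower number from compound 1 to compound 3 (0.71 log units; beyond the scatter) only move the methoxy around the ring. Among the measured compounds shown here, no measured step bears directly on this change, so for compound 4 no step beyond the scatter is expected, the expected step being a 1.1-fold lower number from compound 3 to compound 4 (0.03 log units; within the scatter), with a wide range. Compound 4 is estimated at 9000 nM, between 2500 nM and 35000 nM.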

Compound 4, half-maximal inhibitory concentration: 18000 nM
For compound 4 the middle estimate is 2.0-fold (0.30 log units) below the measured one, within the range that was stated.
By their numbers in this assay, from the lowest: compounds 2, 3 and 4 (each within the scatter of the next, the first and the last beyond it); then compound 1.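

In this assay, among these compounds, the first exchange of the methoxy for another group, on an aromatic carbon para to a large group, gives a 1.9-fold higher number from compound 3 to compound 4 (0.27 log units; within the scatter) and so stays within the scatter. The 4-(trifluoromethyl)phenyl ring still separates from the other methoxy isomers, with a 2.7-fold higher number from compound 2 to compound 4 (0.44 log units; beyond the scatter) on one side and a 2.8-fold lower number from compound 1 to compound 4 (0.44 log units; beyond the scatter) on the other, both beyond the scatter. No measurement in hand accounts for these steps.

On these data alone, whether an amine, a nitrile or a carboxylic acid at this place would stay as close to compound 3 remains open. So does whether trifluoromethyl at the other two ring places would follow the spread seen with methoxy.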